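A few compounds are considered here, and "the series" means these few. Any claim that something is new, unique, unknown or untested is made for them only; others in the source may bear on it.

Measured in a functional assay on the whole organism with Rattus norvegicus as the target; on this read-out lower numbers stand for an effect already at smaller amounts and higher numbers for an effect only at larger amounts of compound:
- Compound 1 `CCN(CCNC(=O)c1cc(Cl)c(N)cc1OC)Cc1ccoc1`: 3 mg/kg
- Compound 2 `CCN(CCNC(=O)c1cc(Cl)c(N)cc1OC)Cc1ccccn1`: 30 mg/kg
- Compound 3 `CCN(CCNC(=O)c1cc(Cl)c(N)cc1OC)Cc1ccc(OC)cc1`: 0.2 mg/kg

Compound 3 has the lowest number of the three, and its steps to both others lie beyond the scatter. Compound 4 `CCN(CCNC(=O)c1cc(Cl)c(N)cc1OC)Cc1ccc(Cl)cc1` differs from it as follows: chloro in place of methoxy on an aromatic carbon. This is chloro in place of methoxy on an aromatic carbon.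

The measured steps that bear on this change all exchange the whole ring: a 15-fold lower number from compound 1 to compound 3 (1.18 log units; beyond the scatter) and a 150-fold lower number from compound 2 to compound 3 (2.18 log units; beyond the scatter), both large, and a 10-fold higher number from compound 1 to compound 2 (1.00 log units; beyond the scatter), modest. None of them alters only the group on the 4-methoxyphenyl ring, so they give no direct size for this exchange. A smaller change is expected here, and the estimated shift is a 2.5-fold higher number from compound 3 to compound 4 (0.40 log units; beyond the scatter), although its direction remains uncertain. Compound 4 is estimated at 0.5 mg/kg, with an expected range of 0.1 mg/kg to 3 mg/kg.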

Compound 4, dose for half-maximal effect: 0.24 mg/kg
For compound 4 the middle estimate is 2.1-fold (0.32 log units) above the measured one, within the range that was stated.
By their numbers in this assay, from the lowest: compounds 3 and 4 (each within the scatter of the next); then compound 1; then compound 2.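

In this assay the step of a 1.2-fold higher number from compound 3 to compound 4 (0.08 log units; within the scatter) shows that this place on the ring, para to a large group, takes chloro as well as methoxy. The low number therefore does not rest on methoxy alone: the 4-chlorophenyl compound keeps its distance from the other rings, with a 130-fold lower number from compound 2 to compound 4 (2.10 log units; beyond the scatter) and a 13-fold lower number from compound 1 to compound 4 (1.10 log units; beyond the scatter) on the same scale. Nothing measured here gives a reason for these numbers.

On these data alone, whether a hydroxyl, an amine or a carboxylic acid at this place would keep the number stays open. So does the outcome for a longer alkoxy chain there.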